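The source may report more compounds than this note shows. Statements on the series, on what has been measured and on what is new or still open speak of the compounds shown alone.

Compound 1 `COc1ccc(-c2c(C(=O)c3cc(OC)c(OC)c(OC)c3)sc3ccccc23)cc1`: 1700 nM
Compound 2 `COc1ccc(Nc2c(C(=O)c3cc(OC)c(OC)c(OC)c3)sc3ccccc23)cc1`: 2900 nM

Both values come from a functional assay on K562 cells (Homo sapiens) for antiproliferative activity, read by MTT assay, with a stated time of 72 h; on this read-out higher numbers stand for weaker inhibition and lower numbers for stronger inhibition. Only these two compounds have been measured so far, and compound 2 at 2900 nM lies within the scatter of compound 1. Going by the values given here, the one measured step is a 1.7-fold higher number from compound 1 to compound 2 (0.23 log units; within the scatter), made by putting (4-methoxyphenyl)amino in place of 4-methoxyphenyl on an aromatic carbon.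

Compound 3 `CCOc1ccc(Nc2c(C(=O)c3cc(OC)c(OC)c(OC)c3)sc3ccccc23)cc1` keeps the core and the linking amino group of compound 2 and changes only the end of the chain: methyl in place of hydrogen on a saturated chain carbon bound to an oxygen on an aromatic ring. In other words, methoxy becomes ethoxy, and 4-methoxyphenyl becomes 4-ethoxyphenyl.

No measured step covers this change, so its size and direction are not shown directly. The nearest evidence is the step from compound 1 to compound 2, which changed a different place and stayed within the scatter at a 1.7-fold higher number from compound 1 to compound 2 (0.23 log units; within the scatter). That is thin support, and it gives no direction. No shift beyond the scatter is therefore expected in this assay, and the estimated step is a 1.0-fold higher number from compound 2 to compound 3 (0.01 log units; within the scatter). The expected value for compound 3 is 3000 nM, with an estimated range of 1200 nM to 7500 nM.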

Compound 3, half-maximal inhibitory concentration: 200 nM
Estimate against measurement, compound 3: 15-fold (1.18 log units) above; the measured number lies below the stated range.
By their numbers in this assay, from the lowest: compound 3; then compounds 1 and 2 (each within the scatter of the next).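

In this assay, going by these compounds alone, the end of the chain on the aromatic ring proves to be a responsive place: going from methoxy to ethoxy, which puts one methyl on a saturated chain carbon bound to an oxygen on an aromatic ring, gives a 15-fold lower number from compound 2 to compound 3 (1.16 log units; beyond the scatter), whereas the one earlier step stayed within the scatter. The wider change, which swaps the directly linked 4-methoxyphenyl group for an amino-linked 4-ethoxyphenyl group, gives an 8.5-fold lower number from compound 1 to compound 3 (0.93 log units; beyond the scatter), so with the ethoxy end in place the amino-linked compound also stands apart from the directly linked 4-methoxyphenyl compound. Nothing available explains how a single added methyl produces a step of this size.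

The compounds shown leave open whether a propoxy, isopropoxy or longer chain at this place would extend the step, hold it or reverse it. On these data alone, it also remains open whether the same step from methoxy to ethoxy would appear on a 4-ethoxyphenyl group attached directly to the core, without the amino link.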